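Working notes: 4-methoxyphenyl in place of 3,4-dichlorophenyl

The source may report more compounds than this note shows. Statements on the series, on what has been measured and on what is new or still open speak of the compounds shown alone.

Measured so far in a functional assay on L1210 cells (Mus musculus) for antiproliferative activity, with a stated time of 48 h; on this read-out lower numbers stand for stronger inhibition and higher numbers for weaker inhibition
- compound 1 `C=C(Br)C(=O)Nc1ccc(/C=C/C(=O)c2ccccc2)cc1` gives 5000 nM
- compound 2 `C=C(Br)C(=O)Nc1ccc(/C=C/C(=O)c2ccc(Cl)cc2)cc1` gives 1100 nM
- compound 3 `C=C(Br)C(=O)Nc1ccc(/C=C/C(=O)c2ccc(Cl)c(Cl)c2)cc1` gives 2100 nM

Of these three numbers, compound 3 (2100 nM) stands within the scatter of compound 2 (a 1.9-fold higher number from compound 2 to compound 3 (0.28 log units; within the scatter)) and clearly apart from compound 1 (a 2.4-fold lower number from compound 1 to compound 3 (0.38 log units; beyond the scatter)). The next analogue, compound 4 `C=C(Br)C(=O)Nc1ccc(/C=C/C(=O)c2ccc(OC)cc2)cc1`, differs from it as follows: 4-methoxyphenyl in place of 3,4-dichlorophenyl on a carbonyl carbon. The bearing steps at this aryl group are small, the largest being modest (a 4.5-fold lower number from compound 1 to compound 2 (0.66 log units; beyond the scatter)). Among the compounds with values here, no measured compound carries a methoxy group, so the direction stays open. The expected result in this assay is a 1.2-fold lower number from compound 3 to compound 4 (0.07 log units; within the scatter) (no step beyond the scatter is anticipated). For compound 4 the estimate is 1800 nM (expected range 600 nM to 5000 nM).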

Compound 4, half-maximal inhibitory concentration: 980 nM
Compound 4: middle estimate off by 1.8-fold (0.26 log units), on the high side, within the range that was stated.
By their numbers in this assay, from the lowest: compounds 4, 2 and 3 (each within the scatter of the next, the first and the last beyond it); then compound 1.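

In this assay, methoxy on the aromatic ring at this position matches chloro (a 1.1-fold lower number from compound 2 to compound 4 (0.05 log units; within the scatter)) and stands clearly apart from hydrogen (a 5.1-fold lower number from compound 1 to compound 4 (0.71 log units; beyond the scatter)), so the lower number seen with chloro is not confined to that one group. The 4-methoxyphenyl group also separates from 3,4-dichlorophenyl (a 2.1-fold lower number from compound 3 to compound 4 (0.33 log units; beyond the scatter)), a gap that the two chloro compounds alone did not show. No measurement at hand accounts for these differences.

Open, going by these compounds, is whether an amine or a carboxylic acid in place of methoxy keeps the number near those of compound 2 and compound 4. A longer chain, such as ethoxy or butoxy, also remains to be read at this position.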